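The compounds below may be only part of what the source reports. "The series", "measured", "known", "first", "only" and "open" are said of these compounds alone.

Of the compounds shown here, three have so far been tested in a functional assay on DU-145 cells (Homo sapiens) for inhibition, read by trypan blue exclusion, with a stated time of 96 h; a higher number here means a weaker inhibitor of growth, a lower number a stronger inhibitor of growth. Compound 3 `COc1ccccc1/C=C(\C(=O)c1ccc(Cl)cc1)S(=O)(=O)c1ccc(C)cc1` gives 1000 nM in this assay. Compound 1 `COc1ccccc1/C=C(\C(=O)c1ccc(Br)cc1)S(=O)(=O)c1ccc(C)cc1` is its counterpart in which one change has been made: bromo in place of chloro on an aromatic carbon. In this assay compound 1 gives 1000 nM, so the step of no change at the digits printed from compound 3 to compound 1 (within the scatter) lies within the scatter. Compound 2 `O=C(O)c1ccc(C(=O)/C(=C\c2ccc(Cl)c([N+](=O)[O-])c2)SCc2ccc(Cl)cc2)cc1` is built on a different core, and how that core differs from the core of compound 3 is not broken down here. In this assay compound 2 gives 1000 nM, level with compounds 1 and 3 at the digits given.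

Compound 4 `O=C(O)c1ccc(C(=O)/C(=C\c2ccc(Br)c([N+](=O)[O-])c2)SCc2ccc(Cl)cc2)cc1` has not yet been measured. It arises from compound 2 by bromo in place of chloro on an aromatic carbon. Among the measured compounds shown here, this is the same kind of change as the one from compound 3 to compound 1, though the place is not the same: here the carbon is ortho to a nitro group as well as para to a large group, whereas before it was only para to a large group. Because the earlier step of no change at the digits printed from compound 3 to compound 1 (within the scatter) showed no change within the scatter, a step of about no change at the digits printed from compound 2 to compound 4 (within the scatter) is expected here. Compound 4 is therefore estimated at 1000 nM in this assay, between 500 nM and 2000 nM.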

Compound 4, concentration for 50% growth inhibition in the DU-145 assay: < 1000 nM
Compound 4: no number, only a limit; the forecaster's own chance of this, stated with the estimate: 20%; the middle value sits exactly at the limit.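

In the DU-145 assay compound 4 gives < 1000 nM, which is a limit of the assay and not a number. In the DU-145 assay the step with bromo in place of chloro can therefore be read only as a number no higher from compound 2 to compound 4 (the limit leaves the size open), and setting it beside the step on the other core does not settle whether the change carries over: the same change on two cores in the DU-145 assay, no change at the digits printed (within the scatter) from compound 3 to compound 1 and a number no higher (the limit leaves the size open) from compound 2 to compound 4; the limit leaves it open whether they differ. This shows that the change did not leave compound 4 a weaker inhibitor of growth than compound 2, but it does not show how large the step is, or whether there is any real step at all.

In a physicochemical assay for solubility (on this read-out lower numbers stand for lower solubility and higher numbers for higher solubility), compound 2 gives < 1000 ug/mL, which is a limit of the assay and not a number. In the physicochemical assay compound 4 gives < 1000 ug/mL, which is also a limit of the assay and not a number. In the physicochemical assay the step between compound 2 and compound 4 cannot be read either: the limit of < 1000 ug/mL in the physicochemical assay, at which 2 of the 2 values shown sit. Still open, as far as these compounds go, are how an amine or an iodo group on that aromatic carbon would behave, and whether the change gives the same step on both cores when every value is an actual number rather than a limit.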